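The compounds below may be only part of what the source reports. "The series", "measured", "known", "first", "only" and "open" are said of these compounds alone.

Compound 1 `CC(C)=CCC1Cc2c(OCCCNS(=O)(=O)c3ccc(Cl)cc3)cc(=O)n(CCCO)c2CC1(C)C` sets the starting point: in a functional assay on PANC-1 cells (Homo sapiens) for inhibition, read by MTT assay, with a stated time of 24 h, tested at 10 uM (a lower number here means less inhibition, a higher number more inhibition at the concentration tested (going by the name of the read-out)), compound 1 gives 9.8%. Compound 2 `CC(C)=CCC/C(C)=C/CC1Cc2c(OCCCNS(=O)(=O)c3ccc(Cl)cc3)cc(=O)n(CCCO)c2CC1(C)C` carries a longer chain on the saturated ring of the shared core, and in this assay compound 2 gives 16.1%. Within the data shown here, the single measured step, a number 6.3 percentage points higher from compound 1 to compound 2 (within the scatter), leaves the two numbers within the scatter of each other, so compound 2 stands on a number that cannot be told apart from that of compound 1.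

Compound 3 `CC(C)=CCC/C(C)=C/CC1Cc2c(OCCCOc3ccc([N+](=O)[O-])cc3)cc(=O)n(CCCO)c2CC1(C)C` differs from compound 2 at the far end of the side chain: 4-nitrophenoxy in place of ((4-chlorophenyl)sulfonyl)amino on a saturated chain carbon, three bonds along the chain from an oxygen on an aromatic ring. Among the measured compounds shown here, no measured step touches this part of the molecule; the one known step concerns the chain on the saturated ring only, so it offers no guide to the size or direction of this change. The shared core and the remaining side chains are unchanged, and both measured numbers sit low in this assay. Compound 3 is therefore expected to give a step of a number 1.1 percentage points lower from compound 2 to compound 3 (within the scatter), meaning no change beyond the scatter. The estimate for compound 3 in this assay is 15%, expected to fall between 4% and 32%.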

Compound 3, a percentage reported as inhibition, at one concentration (the size of the read-out at that concentration, not a potency): 9.8%
Compound 3: the middle estimate sits 5.2 percentage points above what was measured; measured number inside the range.
By their numbers in this assay, from the lowest: compounds 1, 3 and 2 (each within the scatter of the next).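

In this assay, among these compounds, the far end of the side chain is probed for the first time, and exchanging ((4-chlorophenyl)sulfonyl)amino for 4-nitrophenoxy gives a number 6.3 percentage points lower from compound 2 to compound 3 (within the scatter). This exchange takes away the sulfur and the chlorine and replaces the sulfonyl-linked amino end with an aryl ether, yet the two end groups cannot be told apart in this read-out at the concentration tested. No supporting data bear on this result.

It remains open whether any group at this position can move the number beyond the scatter, since only these two end groups are shown here and they share a single chain on the saturated ring. From the compounds shown here alone, what an amine or a carboxylic acid in place of 4-nitrophenoxy would give on that saturated chain carbon also remains open.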